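The compounds below may be only part of what the source reports. "The series", "measured", "known", "first", "only" and "open" are said of these compounds alone.

Of the compounds shown here, three sharing one core have been measured in a functional assay on DU-145 cells (Homo sapiens) for inhibition, read by trypan blue exclusion, with a stated time of 96 h; on this read-out lower numbers stand for stronger inhibition of growth and higher numbers for weaker inhibition of growth: compound 1 (`COc1ccccc1/C=C(/SCc1ccc(F)cc1)C(=O)c1ccc(Br)cc1`) gives 10000 nM, compound 2 (`O=C(/C(=C\c1c[nH]c2ccc(Cl)cc12)SCc1ccc(F)cc1)c1ccc(Br)cc1`) gives 1000 nM, and compound 3 (`CN(C)c1ccc(/C=C(/SCc2ccc(F)cc2)C(=O)c2ccc(Br)cc2)cc1`) gives 50000 nM. Compound 3 therefore stands highest of the three, and so shows the weakest inhibition of growth, with both gaps beyond the scatter: a 5.0-fold higher number from compound 1 to compound 3 (0.70 log units; beyond the scatter) and a 50-fold higher number from compound 2 to compound 3 (1.70 log units; beyond the scatter). Compound 4 (`COc1ccc(/C=C(/SCc2ccc(F)cc2)C(=O)c2ccc(Br)cc2)cc1O`) keeps the core and changes only the group on a double-bonded chain carbon bound to a double-bonded chain carbon: 3-hydroxy-4-methoxyphenyl in place of 4-(dimethylamino)phenyl on a double-bonded chain carbon bound to a double-bonded chain carbon. Within the data shown here, no measured compound carries this exact group, so the evidence is indirect. All three measured steps concern this same place, and they range from modest, a 10-fold lower number from compound 1 to compound 2 (1.00 log units; beyond the scatter), to large. The closest guide is compound 1, which also has a methoxy group on its phenyl ring and lies on the lower side of compound 3, as a 5.0-fold higher number from compound 1 to compound 3 (0.70 log units; beyond the scatter) shows. A modest to large drop is therefore expected, an estimated 13-fold lower number from compound 3 to compound 4 (1.10 log units; beyond the scatter). For compound 4 the expected value is 4000 nM, with an estimated range of 500 nM to 20000 nM.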

Compound 4, concentration for 50% growth inhibition: 1000 nM
The estimate for compound 4 lay 4.0-fold (0.60 log units) above the measured number; low and high end bracket the measured number.
By their numbers in this assay, from the lowest: compounds 2 and 4 (each within the scatter of the next); then compound 1; then compound 3.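

The 3-hydroxy-4-methoxyphenyl group gives a 50-fold lower number from compound 3 to compound 4 (1.70 log units; beyond the scatter) and a 10-fold lower number from compound 1 to compound 4 (1.00 log units; beyond the scatter), so the kind of substitution on a phenyl ring at this place separates these compounds widely. With no change at the digits printed from compound 2 to compound 4 (within the scatter), compound 4 also shows that among these compounds the 5-chloro-1H-indol-3-yl group is not needed to reach the level of compound 2. Nothing given here accounts for these differences.

The compounds shown do not separate the contributions of the hydroxy and methoxy groups, as none carries a phenyl ring with the hydroxy group alone or with a methoxy group in the same arrangement as compound 4. Also open, as far as these compounds go, is how a carboxylic acid or a primary amine in place of the hydroxy group would fare at this place.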